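A few compounds are considered here, and "the series" means these few. Any claim that something is new, unique, unknown or untested is made for them only; others in the source may bear on it.

Measured compounds:
- compound 1, `C=CC(=O)N1CC[C@H](N2C(=O)N(Cc3ccccc3)Cc3cnc(Nc4ccc(N5CCN(C)CC5)cc4OC)nc32)C1`, 175 nM
- compound 2, `C=CC(=O)N1CC[C@H](N2C(=O)N(c3ccccc3)Cc3cnc(Nc4ccc(N5CCN(C)CC5)cc4)nc32)C1`, 1450 nM

Within the data shown here, in an ADME assay on the whole organism (strain Sprague-Dawley) for pharmacokinetics, with Rattus norvegicus as the target, read by LC-MS, at a dose of 25 mg/kg by the oral route (on this read-out lower numbers stand for lower exposure and higher numbers for higher exposure at the dose given), compound 2 stands highest of the two numbers; the only other value, that of compound 1, is lower by a gap beyond the usual scatter, but the two structures differ in more than one place, so the gap cannot be tied to any single change.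

Compound 3, `C=CC(=O)N1CC[C@H](N2C(=O)N(c3ccccc3)Cc3cnc(Nc4ccc(N5CCN(C)CC5)cc4OC)nc32)C1`, is not yet measured. It differs from compound 2 by methoxy in place of hydrogen on an aromatic carbon. Among the measured compounds shown here, no single-change step between measured compounds shows what this change does. Compound 1 carries the same methoxy and sits lower, yet it also differs at the ring on the urea nitrogen. The expectation is a modest decrease, near the edge of the scatter, as a 1.8-fold lower number from compound 2 to compound 3 (0.26 log units; within the scatter). Compound 3 is estimated at 800 nM, with a range from 250 nM to 2600 nM.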

Compound 3, maximal plasma concentration: 1080 nM
Compound 3: the middle estimate sits 1.4-fold (0.13 log units) below what was measured; measured number inside the range.
By their numbers in this assay, from the lowest: compound 1; then compounds 3 and 2 (each within the scatter of the next).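

In this assay, methoxy in place of hydrogen on the aromatic carbon ortho to a large group and meta to a 4-methylpiperazin-1-yl group gives a 1.3-fold lower number from compound 2 to compound 3 (0.13 log units; within the scatter) and so stays within the scatter, which means this position accepts the methoxy without a clear shift in the read-out. Phenyl in place of benzyl on the amide-type nitrogen in a ring gives a 6.2-fold higher number from compound 1 to compound 3 (0.79 log units; beyond the scatter) with the methoxy held constant, and of the two single changes now readable, only this one lies beyond the scatter. No measurement on hand accounts for either step.

From the compounds shown here alone, whether a fluorine or a longer ethoxy at the methoxy position would also stay within the scatter remains open. Also open, going by these compounds, is how a pyridine ring or a chain ending in an amine would compare with phenyl on the amide-type nitrogen.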